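The compounds below may be only part of what the source reports. "The series", "measured", "known", "first", "only" and "open" are said of these compounds alone.

Compound 1 `COc1ccc2[nH]c(=O)c(-c3nc4cc(F)ccc4[nH]3)cc2c1` gives > 100000 nM in a functional assay on SK-OV-3 cells (Homo sapiens) for cytotoxicity, read by MTT assay, with a stated time of 48 h (a lower number here means a stronger inhibitor, a higher number a weaker inhibitor), which is a limit of the assay rather than a number. Compound 2 `O=c1[nH]c2ccccc2cc1-c1nc2cc(F)ccc2[nH]1` gives 18300 nM in this assay. Compound 3 `O=c1[nH]c2ccccc2cc1-c1nc2cc([N+](=O)[O-])ccc2[nH]1` gives > 100000 nM in this assay, again a limit of the assay.

Compound 1 thus sits at the limit, as stated by the limit of > 100000 nM in this assay, at which 2 of the 3 values shown sit; only compound 2 returns an actual number. Compound 4 `COc1ccc2[nH]c(=O)c(-c3nc4cc(Cl)ccc4[nH]3)cc2c1` differs from compound 1 by chloro in place of fluoro on an aromatic carbon. Going by the values given here, no measured step swaps fluoro for chloro. The nearest is an at least 5.4-fold higher number from compound 2 to compound 3 (0.73 log units; beyond the scatter), which also replaced fluoro on an aromatic carbon and weakened the compound, while an at least 5.4-fold lower number from compound 1 to compound 2 (0.73 log units; beyond the scatter) concerns the methoxy, which compound 4 keeps. The step of a number no higher from compound 1 to compound 4 (the limit leaves the size open) is therefore expected to be small. Compound 4 is expected to give 100000 nM in this assay, between 30000 nM and 300000 nM, most likely again as a limit.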

Compound 4, half-maximal inhibitory concentration: > 100000 nM
Compound 4: a limit, no number; the forecaster's own chance of this, stated with the estimate: 70%; the middle value lies on the limit itself.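

Going by these compounds alone, compound 1 and compound 4 both end at a limit of the assay rather than a number, so no step between them can be read: the limit of > 100000 nM in this assay, at which 3 of the 4 values shown sit. From the compounds shown here alone, whether chloro in place of fluoro changes the activity at all stays open.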